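The source may hold more compounds than are shown below. What is called first, only, known or untested is meant among the compounds shown, and "the series" means these compounds.

Measured so far in an ADME assay on Raji cells (Homo sapiens) for cytotoxicity, with a stated time of 72 h; a higher number here means that more compound is needed for the effect, a lower number that less compound is needed:
- Compound 1 `CC(=O)c1ccc(NC(=O)Nc2cc(C)nc3ccccc23)cc1` gives > 25000 nM, which is a limit of the assay and not a number.
- Compound 2 `Cc1cc(NC(=O)Nc2cnc3ccccc3c2)c2ccccc2n1` gives > 25000 nM, also a limit.
- Compound 3 `Cc1cc(NC(=O)Nc2cccc(C(C)(C)C)c2)c2ccccc2n1` gives > 25000 nM, again a limit.

Compound 1 stands where every measured compound stands: at the limit of > 25000 nM in this assay, at which 3 of the 3 values shown sit. None of the three measured compounds reached a measurable value, so nothing yet separates compound 1 from compound 2 or compound 3 in this assay.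

The untested compound 4 `CCc1ccc(NC(=O)Nc2cc(C)nc3ccccc23)cc1` differs from compound 1 in one place: ethyl in place of acetyl on an aromatic carbon. Going by the values given here, no pair of measured compounds differs in a single place, so there is no measured step to compare this change against; the only guide is that all three measured compounds sit at the same limit.

For this assay the step from compound 1 to compound 4 is expected to be none beyond the scatter, so that a step that the limit leaves unreadable from compound 1 to compound 4 is estimated to leave compound 4 at the limit as well. Compound 4 is therefore expected to give about 30000 nM, within the range 12000 nM to 80000 nM, and most likely reported only as a limit.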

Compound 4, half-maximal effective concentration: > 25000 nM
Compound 4 was reported as a limit; the forecaster's own chance of this, stated with the estimate: 80%; the middle value does not contradict the limit.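

No size can be read for the change from acetyl to ethyl between compound 1 and compound 4, since both are reported only as limits: the limit of > 25000 nM in this assay, at which 4 of the 4 values shown sit. In this assay the compounds shown leave open which structural change, if any, would give a measurable value.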